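The compounds below may be only part of what the source reports. "The series", "measured", "known", "first", "only" and "open" are said of these compounds alone.

In a functional assay on B16-F10 cells (Mus musculus) for antiproliferative activity, read by MTT assay, with a stated time of 48 h (a lower number here means a stronger inhibitor, a higher number a weaker inhibitor), compound 1 (`COc1ccc(-c2nn(-c3ccccc3)cc2CNc2ccc(Br)cc2)cc1`) gives 8060 nM and compound 2 (`Fc1ccc(NCc2cn(-c3ccccc3)nc2-c2ccc(Cl)cc2)cc1`) gives 2120 nM as the lower of the two numbers, a gap beyond the usual scatter. Compound 3 (`Clc1ccc(-c2nn(-c3ccccc3)cc2CNc2ccc(Br)cc2)cc1`), not yet measured, differs from compound 2 in one place (bromo in place of fluoro on an aromatic carbon), with bromo in place of fluoro on an aromatic carbon. Among the compounds with values here, no measured pair shows this change, so in this assay only a small move toward a higher number, within the scatter, is expected (a 1.2-fold higher number from compound 2 to compound 3 (0.09 log units; within the scatter)). Compound 3 is expected at 2600 nM (estimated range 900 nM to 7000 nM).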

Compound 3, half-maximal inhibitory concentration: 3010 nM
Estimate against measurement, compound 3: 1.2-fold (0.06 log units) below, and the stated range covers the measured number.
By their numbers in this assay, from the lowest: compounds 2 and 3 (each within the scatter of the next); then compound 1.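

The change from (4-fluorophenyl)amino to (4-bromophenyl)amino gives a 1.4-fold higher number from compound 2 to compound 3 (0.15 log units; within the scatter) in this assay, so fluoro and bromo on this aromatic carbon cannot be told apart here. The other exchange, chloro in place of methoxy on an aromatic carbon, gives a 2.7-fold lower number from compound 1 to compound 3 (0.43 log units; beyond the scatter), a modest step beyond the scatter and the first single-place change shown to matter. No evidence available here accounts for either step. On these data alone, what a nitrile or a carboxylic acid would give on either aromatic carbon remains open.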